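This account rests on a few compounds, and the source may have more. Where it says the series, first, only, none or still open, it means among the compounds named here.

Measured compounds:
- compound 1, `COC(=O)/C=C/c1cccc(N(Cc2ccc(/C=C/c3ccccn3)cc2)C(=O)C2CCCCC2)c1`: 309 nM
- compound 2, `COC(=O)/C=C/c1cccc(N(Cc2ccc(/C=C/c3scnc3C)cc2)C(=O)C2CCCCC2)c1`: 227 nM
- compound 3, `COC(=O)/C=C/c1cccc(N(Cc2ccc(C(C)(C)C)cc2)C(=O)C2CCCCC2)c1`: > 1000 nM

In an assay on isolated protein with Bile acid receptor (Homo sapiens) as the target (a lower number here means that less compound is needed, a higher number that more compound is needed for the effect), compound 1 gives 309 nM. Compound 2 gives 227 nM in this assay, and the change a 1.4-fold lower number from compound 1 to compound 2 (0.13 log units; within the scatter) lies within the scatter. Compound 3 is different: in this assay compound 3 gives > 1000 nM, which is a limit of the assay and not a number. Its result thus sits at the limit of > 1000 nM in this assay, at which 1 of the 3 values shown sits, so where compound 3 truly stands is known only as a range.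

Compound 4, `CCOC(=O)/C=C/c1ccc(CN(C(=O)C2CCCCC2)c2cccc(/C=C/C(=O)OC)c2)cc1`, differs from compound 3 in one place: 2-(ethoxycarbonyl)ethenyl in place of tert-butyl on an aromatic carbon. Among the measured compounds shown here, two measured steps bear on this change. The step of an at least 3.2-fold higher number from compound 1 to compound 3 (0.51 log units; beyond the scatter) and the step of an at least 4.4-fold higher number from compound 2 to compound 3 (0.64 log units; beyond the scatter) both show that trading a two-carbon chain carrying a ring for tert-butyl on that aromatic carbon raises the number by a modest amount or more. The change from compound 3 to compound 4 runs the other way, replacing tert-butyl with a two-carbon chain that ends in an ester rather than a ring. The expectation is therefore a lower number for compound 4 than for compound 3, and the expected step is an at least 2.0-fold lower number from compound 3 to compound 4 (0.30 log units; that floor lies within the scatter). The estimate for compound 4 in this assay is 500 nM, with a range from 150 nM to 2000 nM.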

Compound 4, half-maximal effective concentration: > 1000 nM
Compound 4: a limit, no number; the forecaster's own chance of this, stated with the estimate: 30%; middle value at least 2.0-fold (0.30 log units) away from the limit.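

Keeping the double-bonded chain on this aromatic carbon but ending it in ethoxycarbonyl instead of a ring gives an at least 4.4-fold higher number from compound 2 to compound 4 (0.64 log units; beyond the scatter), and the same change gives an at least 3.2-fold higher number from compound 1 to compound 4 (0.51 log units; beyond the scatter). In this assay, then, the two-carbon chain alone does not bring the lower numbers of compound 1 and compound 2, and within these two pairs the pyridin-2-yl or 4-methyl-1,3-thiazol-5-yl ring at its end makes the difference from ethoxycarbonyl. Compound 4 sits at a limit of the assay and not at a number, as does compound 3, so the step between these two cannot be read: the limit of > 1000 nM in this assay, at which 2 of the 4 values shown sit.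

Going by these compounds, how far past that limit compound 3 and compound 4 truly lie stays unknown, so tert-butyl and the 2-(ethoxycarbonyl)ethenyl group cannot be ranked against each other. Also open, on these data alone, is what other ends on the same chain would do, for example a carboxylic acid in place of the ester, an amine, or a plain phenyl ring, and whether any of these would bring the number back to the level of compound 1 and compound 2.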